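The source may hold more compounds than are shown below. What is called first, only, known or untested is meant among the compounds shown, and "the series" means these compounds.

Compound 1 `C#CCN(Cc1ccc2nc(C)nc(O)c2c1)c1ccc(S(N)(=O)=O)cc1`: 20000 nM
Compound 2 `C#CCN(Cc1ccc2nc(C)nc(O)c2c1)c1ccc(S(=O)(=O)C(F)(F)F)cc1`: 2750 nM

Both values come from a functional assay on L1210 cells (Mus musculus) for inhibition; a lower number here means a stronger inhibitor, a higher number a weaker inhibitor. Compound 2 has the lower number of the two, so it is the stronger inhibitor of this pair. Compound 3 `C#CCN(Cc1ccc2nc(C)nc(O)c2c1)c1ccc(S(=O)(=O)N2CCN(C)CC2)cc1` has not yet been measured. It differs from compound 2 by 4-methylpiperazin-1-yl in place of trifluoromethyl on a sulfonyl sulfur, which is 4-methylpiperazin-1-yl in place of trifluoromethyl on a sulfonyl sulfur.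

Among the compounds with values here, only one measured step changes this same place: a 7.3-fold lower number from compound 1 to compound 2 (0.86 log units; beyond the scatter). Within the data shown here, this modest step shows that the group on the sulfur can shift the number, but no measured compound carries 4-methylpiperazin-1-yl. Since trifluoromethyl gave the lower number of the two groups tried, replacing it is expected to raise the number in this assay, by a step of about that size. The expected step is a 2.9-fold higher number from compound 2 to compound 3 (0.46 log units; beyond the scatter). The estimate for compound 3 is 8000 nM, with an expected range from 2000 nM to 30000 nM.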

Compound 3, half-maximal inhibitory concentration: > 10000 nM
Compound 3 gave a limit, no number; the forecaster's own chance of this, stated with the estimate: 10%; at least 1.2-fold (0.09 log units) between middle value and limit.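

The reading for compound 3 in this assay is a limit of the assay and not a number: the limit of > 10000 nM in this assay, at which 1 of the 3 values shown sits.

Even so, 4-methylpiperazin-1-yl in place of trifluoromethyl on the sulfonyl sulfur gives an at least 3.6-fold higher number from compound 2 to compound 3 (0.56 log units; beyond the scatter), so trifluoromethyl now keeps the lower number against a ring-bearing group as well as against amino. The step between compound 1 and compound 3 cannot be read, so these two groups cannot be ranked against each other.

Going by these compounds, the true number for compound 3 stays open, and so does whether the ring itself matters or any group other than trifluoromethyl would raise the number. What a plain methyl or a dimethylamino group on the sulfonyl sulfur would give cannot be told from these three compounds.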